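Methyl for hydroxy on the ketone-bearing ring

The compounds below may be only part of what the source reports. "The series", "measured", "known", "first", "only" and "open" are said of these compounds alone.

Measured compounds:
Compound 1 `Cc1c(OCCCCOc2ccc(F)c(C(=O)O)c2)ccc(C(=O)CC2CCCC2)c1C`: "not determined" (no result reported) in an assay on HEK293 cells for positive allosteric modulation of metabotropic glutamate receptor 2 (Rattus norvegicus), read by thallium flux, with a stated time of 2.5 min; a higher number here means that more compound is needed for the effect, a lower number that less compound is needed
Compound 2 `Cc1c(OCCCCOc2ccc(C(=O)O)c(Cl)c2)ccc(C(=O)CC2CCCC2)c1O`: 510 nM in this assay

Within the data shown here, compound 2 holds the only number in the set: in this assay compound 2 gives 510 nM. Compound 1, the further entry, stands as "not determined" (no result reported) in this assay, so compound 2 cannot be placed relative to anything else.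

Compound 3 `Cc1c(OCCCCOc2ccc(C(=O)O)c(Cl)c2)ccc(C(=O)CC2CCCC2)c1C` is not yet measured. It differs from compound 2 in one place: methyl in place of hydroxy on an aromatic carbon. Among the measured compounds shown here, no pair of measured compounds shows what this exchange does, so there is no measured step to lean on.

Compound 3 is expected to remain near compound 2, because compound 2 gives 510 nM and the exchange touches a single heavy atom on the ring that carries the (cyclopentylmethyl)carbonyl group. A step of a 1.5-fold higher number from compound 2 to compound 3 (0.17 log units; within the scatter) is the expectation, lying within the usual scatter or only slightly beyond it. The estimate for compound 3 in this assay is 750 nM, with a range from 200 nM to 2800 nM.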

Compound 3, half-maximal effective concentration: 2420 nM
For compound 3 the middle estimate is 3.2-fold (0.51 log units) below the measured one; low and high end bracket the measured number.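

The hydroxy on the aromatic carbon ortho to the (cyclopentylmethyl)carbonyl group is not a freely exchangeable site in this assay: methyl in its place gives a 4.7-fold higher number from compound 2 to compound 3 (0.68 log units; beyond the scatter), so a change of a single heavy atom here moves the number beyond the usual scatter. Among these compounds, this is the first measured step at this position, and it shows that, of these two groups, the hydroxy goes with less compound being needed for the effect. The exchange removes a hydrogen-bond donor and a hydrogen-bond acceptor and puts a carbon in place of an oxygen, but no measurement at hand separates these differences or accounts for the step.

With only hydroxy and methyl compared, the compounds shown leave open how an amine, a methoxy group or a fluorine on this same carbon would compare with compound 2. They also leave open whether the step of this exchange would hold with another group in place of the chlorine on the ring that bears the carboxylic acid.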